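Propoxy for sulfanyl on a weakly cytotoxic pair

A few compounds are considered here, and "the series" means these few. Any claim that something is new, unique, unknown or untested is made for them only; others in the source may bear on it.

In a functional assay on K562 cells (Homo sapiens) for cytotoxicity (on this read-out lower numbers stand for stronger inhibition and higher numbers for weaker inhibition), compound 1 `CCC(CO)Nc1nc(NCc2ccccc2)c2nc(O)n(C(C)C)c2n1` gives 74000 nM, while compound 2 `CCC(CO)Nc1nc(NCc2ccccc2)c2nc(S)n(C(C)C)c2n1` gives 154000 nM. Compound 2 therefore stands at the higher of the two numbers, with the weaker inhibition so far. Compound 3 `CCCOc1nc2c(NCc3ccccc3)nc(NC(CC)CO)nc2n1C(C)C` has not yet been measured. It keeps the shared core and differs from compound 2 at a single place: propoxy in place of sulfanyl on an aromatic carbon. This is propoxy in place of sulfanyl on an aromatic carbon, the same carbon that separates compound 1 from compound 2.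

Among the measured compounds shown here, only one measured step bears on this change: a 2.1-fold higher number from compound 1 to compound 2 (0.32 log units; beyond the scatter), a modest step with sulfanyl in place of hydroxy. Compound 3, like compound 1, carries oxygen on that carbon, so a modest move back towards lower numbers in this assay is expected rather than a further rise. For the measured compounds named here, this is thin support, as no measured compound carries an alkyl chain there. The expected change is a 2.1-fold lower number from compound 2 to compound 3 (0.31 log units; beyond the scatter). For compound 3 the estimated value is 75000 nM, with an expected range from 25000 nM to 180000 nM.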

Compound 3, half-maximal inhibitory concentration: 20000 nM
Compound 3: the middle estimate sits 3.8-fold (0.57 log units) above what was measured; the measured number lies below the stated range.
By their numbers in this assay, from the lowest: compound 3; then compound 1; then compound 2.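

In this assay, among the compounds shown here, this carbon had so far carried only hydroxy and sulfanyl, and the new result shows that it can also take a propoxy chain, with a 7.7-fold lower number from compound 2 to compound 3 (0.89 log units; beyond the scatter) and the lowest number of the three compounds. Oxygen on that carbon does not by itself set the level: compound 1 has it too, yet placing a propyl group on that oxygen gives a 3.7-fold lower number from compound 1 to compound 3 (0.57 log units; beyond the scatter), so what is attached to the oxygen also matters in this series. Nothing at hand explains why the number falls with this change.

With only one chain at this position, the compounds shown do not reveal whether a shorter methoxy group or a longer butoxy group would give a lower or a higher number than propoxy. They also leave open whether the oxygen link is needed, which a propylsulfanyl or propylamino group on the same carbon, each carrying the same three-carbon chain, would help to decide.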